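This account rests on a few compounds, and the source may have more. Where it says the series, first, only, none or still open, it means among the compounds named here.

The measured compounds:
Compound 1 `CC(C)n1ncc2c(C(=O)NCc3cn(-c4ccccc4F)nn3)cccc21` gives > 40000 nM in a functional assay on HepG2 cells (Homo sapiens) for inhibition, read by MTT assay, with a stated time of 72 h (on this read-out lower numbers stand for stronger inhibition and higher numbers for weaker inhibition), which is a limit of the assay and not a number.
Compound 2 `CC(C)n1ncc2c(C(=O)NCc3cn(-c4ccc(C(F)(F)F)cc4)nn3)cccc21` gives > 40000 nM in this assay, again a limit of the assay and not a number.

For the measured compounds named here, compound 2 therefore stands at a limit in this assay, with no number of its own, and the one further value shown is also a limit. The step from compound 1 to compound 2, a step that the two limits leave unreadable from compound 1 to compound 2, cannot be read, because the limit of > 40000 nM in this assay, at which 2 of the 2 values shown sit, records that both values sit at the same limit. The change to compound 3 `CC(C)n1ncc2c(C(=O)NCc3cn(Cc4ccccc4)nn3)cccc21` is benzyl in place of 4-(trifluoromethyl)phenyl on an aromatic nitrogen. Going by the values given here, no measured step bears on this change with a readable size: the single step available is unreadable at both ends, so it neither supports nor rules out a change beyond the scatter in this assay. With both neighbours at the limit, compound 3 is expected to remain at or near that limit. The step that the limit leaves unreadable from compound 2 to compound 3 is estimated as no readable change. Compound 3 is expected at 50000 nM, with a range from 15000 nM to 200000 nM, and most likely reported only as a limit.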

Compound 3, half-maximal inhibitory concentration: 13700 nM
For compound 3 the middle estimate is 3.6-fold (0.56 log units) above the measured one, and the stated range ends above it.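

In this assay, benzyl in place of 4-(trifluoromethyl)phenyl on the aromatic nitrogen gives an at least 2.9-fold lower number from compound 2 to compound 3 (0.46 log units; beyond the scatter), and benzyl in place of 2-fluorophenyl on the same nitrogen gives an at least 2.9-fold lower number from compound 1 to compound 3 (0.46 log units; beyond the scatter). For the compounds shown here, this shows for the first time that a change at this position alone can bring a compound with this shared core off the limit, with both steps beyond the scatter, whereas the two earlier compounds offered no number to compare. Compound 3 is thus the only one of the three with a number of its own, so each step gives only a minimum size, and the step between the two aryl compounds cannot be read: the limit of > 40000 nM in this assay, at which 2 of the 3 values shown sit.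

The compounds shown leave open whether the gain depends on the benzyl group as such, since an unsubstituted phenyl, a longer chain such as phenethyl, and a benzyl ring bearing fluorine or trifluoromethyl do not appear among them. On these data alone, it also remains open whether an amine or a carboxylic acid on that ring would extend the step or return a compound to the limit.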